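Extending a Nitrile Chain and Its Effect on Cytotoxicity

The source may hold more compounds than are shown below. What is called first, only, known or untested is meant among the compounds shown, and "the series" means these compounds.

Three measured compounds share one core and differ only in the chain that carries a nitrile on the aromatic nitrogen. Compound 1 `Cc1nc2c(Br)c(Br)c(Br)c(Br)c2n1CC#N` gives 11% in a functional assay on MCF7 cells (Homo sapiens) for cytotoxicity, read by MTT assay, with a stated time of 24 h, tested at 50 uM; a lower number here means a stronger effect, a higher number a weaker effect of the compound at the concentration tested. Compound 3 `Cc1nc2c(Br)c(Br)c(Br)c(Br)c2n1CCC#N` gives 15%, and compound 2 `Cc1nc2c(Br)c(Br)c(Br)c(Br)c2n1CCCCC#N` gives 42%. Among these three numbers compound 3 stands second highest: the step of a number 4 percentage points higher from compound 1 to compound 3 (within the scatter) lies within the scatter, while the step of a number 27 percentage points lower from compound 2 to compound 3 (beyond the scatter) lies beyond it.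

Compound 4 `Cc1nc2c(Br)c(Br)c(Br)c(Br)c2n1CCCC#N` has not yet been measured. The change from compound 3 to compound 4 is cyanomethyl in place of cyano on a saturated chain carbon, two bonds along the chain from an aromatic nitrogen. Going by the values given here, two measured steps bear on it. The step of a number 4 percentage points higher from compound 1 to compound 3 (within the scatter) shows that the same lengthening by one carbon, made one bond closer to the nitrogen, changed little. The step of a number 27 percentage points lower from compound 2 to compound 3 (beyond the scatter) shows that shortening the chain by two carbons lowered the number well beyond the scatter. Compound 4 sits between compound 3 and compound 2 in chain length, so a modest rise is expected. Compound 4 is expected to give 26%, in the range 13% to 40%, which is an estimated step of a number 11 percentage points higher from compound 3 to compound 4 (beyond the scatter).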

Compound 4, a percentage reported as activity, at one concentration (the size of the read-out at that concentration, not a potency): 5%
Beside the measured number, compound 4's estimate is 21 percentage points above it; the measured number lies below the stated range.
By their numbers in this assay, from the lowest: compounds 4, 1 and 3 (each within the scatter of the next); then compound 2.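

In this assay, one more carbon on this chain brings no real change at this position: a number 10 percentage points lower from compound 3 to compound 4 (within the scatter), and a number 6 percentage points lower from compound 1 to compound 4 (within the scatter), so the three shorter chains give numbers within the scatter of each other. The weaker effect appears only with the final lengthening, seen in reverse as a number 37 percentage points lower from compound 2 to compound 4 (beyond the scatter), so the number does not climb steadily with chain length but jumps at the longest chain shown. The size of a one-carbon lengthening therefore depends on the chain it is made on: the same change on two cores in this assay, a number 4 percentage points higher (within the scatter) from compound 1 to compound 3 and a number 37 percentage points higher (beyond the scatter) from compound 4 to compound 2, 33 percentage points apart, beyond the scatter of two such steps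

As far as these compounds go, whether a still longer chain keeps the number as high as in compound 2 or raises it further remains open. Also open, from the compounds shown here alone, is whether an amine or a carboxylic acid at the chain end, in place of the nitrile, would follow the same pattern.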